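Methyl to chloro on the distal phenyl of the triazole

The source may report more compounds than this note shows. Statements on the series, on what has been measured and on what is new or still open speak of the compounds shown alone.

Three compounds of the series have numbers in a functional assay on OVCAR-3 cells (Homo sapiens) for antiproliferative activity, read by MTT assay, with a stated time of 24 h; on this read-out higher numbers stand for weaker inhibition and lower numbers for stronger inhibition. Compound 1 `O=c1[nH]cc(S(=O)(=O)Nc2ccccc2-c2cn(-c3cccc(F)c3)nn2)c(=O)[nH]1` gives only a limit of the assay, > 20000 nM, and no number. Compound 2 `Cc1ccc(-n2cc(-c3cccc(NS(=O)(=O)c4c[nH]c(=O)[nH]c4=O)c3)nn2)cc1` gives 3540 nM in this assay. Compound 3 `Cc1ccc(-n2cc(-c3ccc(NS(=O)(=O)c4c[nH]c(=O)[nH]c4=O)cc3)nn2)cc1` gives 5630 nM in this assay, and the two numbers of compound 2 and compound 3 lie within the scatter of each other, so neither can be placed ahead of the other. For the measured compounds named here, the limit of > 20000 nM in this assay, at which 1 of the 3 values shown sits, is the only other value shown.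

Compound 4 `O=c1[nH]cc(S(=O)(=O)Nc2ccc(-c3cn(-c4ccc(Cl)cc4)nn3)cc2)c(=O)[nH]1` is not yet measured in this assay. It differs from compound 3 by chloro in place of methyl on an aromatic carbon, which in the wider reading is 4-methylphenyl to 4-chlorophenyl. Going by the values given here, no measured pair carries this change, so no step of known size can be pointed to. With the core, the sulfonamide link and the triazole all kept, the expected step from compound 3 to compound 4 is a 1.1-fold lower number from compound 3 to compound 4 (0.05 log units; within the scatter), which is no change beyond the scatter in either direction. On that basis compound 4 is estimated at 5000 nM in this assay, with a range from 2000 nM to 14000 nM.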

Compound 4, half-maximal inhibitory concentration: 2160 nM
Compound 4: middle estimate off by 2.3-fold (0.36 log units), on the high side; the range from low to high includes it.
By their numbers in this assay, from the lowest: compounds 4, 2 and 3 (each within the scatter of the next, the first and the last beyond it). At a limit, above all of these: compound 1.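

In this assay, for the compounds shown here, chloro in place of methyl gives a 2.6-fold lower number from compound 3 to compound 4 (0.42 log units; beyond the scatter), the first step that rests on a single change and the first to be read beyond the scatter. The step is modest, but it shows that the group on the aromatic carbon of the distal phenyl, para to a large group, can move the number on its own, even though the swap leaves the counts of rings, hydrogen-bond donors and hydrogen-bond acceptors unchanged. Nothing among the data shown gives a cause for this step.

Going by these compounds alone, only this one pair carries the change, so it remains open whether chloro in place of methyl gives a step of similar size in the other arrangement of the central phenyl seen in compound 2. Going by these compounds, it also remains open how an amine, a carboxylic acid or a methoxy group on the same carbon would read in this assay, and so whether the step from methyl to chloro marks a trend or stands alone.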